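The source may report more compounds than this note shows. Statements on the series, on what has been measured and on what is new or still open speak of the compounds shown alone.

Measured so far, in a toxicity assay on the whole organism (strain Icem-CET (SPF Caw)) for cytotoxicity, with Mus musculus as the target; a higher number here means that more compound is needed for the effect, a lower number that less compound is needed:

Compound 1 `C=CCNC(=O)/C(C)=C(\C)c1cc(OC)c(OC)c(OC)c1` gives 110 mg/kg.
Compound 2 `C#CCNC(=O)/C(C)=C(\C)c1cc(OC)c(OC)c(OC)c1` gives 160 mg/kg.
Compound 3 `C#CCNC(=O)/C(C)=C(\C)c1ccc(C)cc1` gives 120 mg/kg.

Compound 4 `C=CCNC(=O)/C(C)=C(\C)c1ccc(C)cc1` has not yet been measured in this assay.

Compounds 1 and 2 share one core and differ by a single change, (vinyl in place of ethynyl on a saturated chain carbon bound to an amide-type nitrogen). Its measured step is a 1.5-fold lower number from compound 2 to compound 1 (0.16 log units; within the scatter).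

Compound 4 is built from compound 3 by the same change, (vinyl in place of ethynyl on a saturated chain carbon bound to an amide-type nitrogen), at a place described in the same words. What differs is the core: compound 3 and compound 4 carry a core other than that of compounds 1 and 2, and the difference between the two cores is not broken down here. Compound 3 sits within the scatter of both compound 1 and compound 2, so the new core has not moved the dose by a telling amount on its own.

For compound 4 the expected step is a 1.4-fold lower number from compound 3 to compound 4 (0.15 log units; within the scatter), resting on the earlier step of the same change, because a 1.5-fold lower number from compound 2 to compound 1 (0.16 log units; within the scatter) stayed within the scatter. Compound 4 is therefore estimated at 85 mg/kg in this assay, expected between 50 mg/kg and 150 mg/kg.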

Compound 4, dose for half-maximal effect: 100 mg/kg
Compound 4: middle estimate off by 1.2-fold (0.07 log units), on the low side; low and high end bracket the measured number.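

In this assay, putting vinyl in place of ethynyl on the core of compound 3 gives a 1.2-fold lower number from compound 3 to compound 4 (0.08 log units; within the scatter) and so stays inside the usual spread of repeated measurements. Set beside the earlier step, the result on the second core cannot be told apart from the first: the same change on two cores in this assay, a 1.5-fold lower number (0.16 log units; within the scatter) from compound 2 to compound 1 and a 1.2-fold lower number (0.08 log units; within the scatter) from compound 3 to compound 4, 1.2-fold (0.08 log units) apart, within the scatter of two such steps. This shows that, on these two cores, the swap from propargyl to allyl behaves alike as far as this assay can tell, but both steps are small enough to be scatter, so it does not show that the swap truly shifts the dose or that a larger effect would carry from one core to the other.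

On these data alone, only these two groups appear at this place, so it remains open how a saturated propyl group, a longer chain or an amine there would compare. As far as these compounds go, whether the same step would hold on a third core, such as one carrying a carboxylic acid, also remains open.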